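Working notes: the step from compound 2 to compound 3

The source may hold more compounds than are shown below. What is called first, only, known or untested is meant among the compounds shown, and "the series" means these compounds.

Values so far (an ADME assay on MRC5 cells (Homo sapiens) for cytotoxicity, read by fluorescence and resazurin assay, with a stated time of 3 days; on this read-out lower numbers stand for an effect already at smaller amounts and higher numbers for an effect only at larger amounts of compound)
- compound 1 `O=C1C=CC(O)(c2cn(-c3ccc4ncsc4c3)nn2)C=C1` gives 69 nM
- compound 2 `CCOC(=O)Nc1ccc(S(=O)(=O)n2c(C3(O)C=CC(=O)C=C3)cc3ccccc32)cc1` gives 86 nM

Compound 2 (86 nM) has only compound 1 for comparison, and the two values lie within the scatter of each other, so neither ranks over the other. Compound 3 `O=C1C=CC(O)(c2cc3ccccc3n2S(=O)(=O)c2ccc(CCC(=O)O)cc2)C=C1` carries 2-carboxyethyl in place of (ethoxycarbonyl)amino on an aromatic carbon, para to a large group (2-carboxyethyl in place of (ethoxycarbonyl)amino on an aromatic carbon). Within the data shown here, no measured pair of compounds differs in one place, so the series offers no measured step to carry over to this change. Expected in this assay is a modest move to a higher number, estimated as a 2.3-fold higher number from compound 2 to compound 3 (0.37 log units; beyond the scatter) and resting on the structural change alone. The estimated value for compound 3 is 200 nM within a range from 70 nM to 800 nM (an expectation, not a measurement).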

Compound 3, half-maximal effective concentration: 3300 nM
Beside the measured number, compound 3's estimate is 17-fold (1.22 log units) below it; the whole stated range lies below it.
By their numbers in this assay, from the lowest: compounds 1 and 2 (each within the scatter of the next); then compound 3.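

In this assay, among these compounds, the aromatic carbon para to a large group proves sensitive to what it carries: 2-carboxyethyl in place of (ethoxycarbonyl)amino gives a 38-fold higher number from compound 2 to compound 3 (1.58 log units; beyond the scatter), the first step between compounds differing in one place. The number in this read-out therefore does not follow from the shared core alone, since a single change at this position is enough to move it well beyond the scatter. No measurement at hand bears on the reason for the size of this step.

Open, on these data alone, is whether the step follows the arrival of the 2-carboxyethyl group or the departure of the (ethoxycarbonyl)amino group, which an amine or an ethyl ester of the chain at this place could help separate. Also open, as far as these compounds go, is whether the same change would have a similar effect on the core of compound 1.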